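A few compounds are considered here, and "the series" means these few. Any claim that something is new, unique, unknown or untested is made for them only; others in the source may bear on it.

The three measured compounds and their numbers:

Compound 1, `FC(F)(F)c1cccc(/N=N/c2ccc(NC[C@@H]3CCCN4CCCC[C@H]34)c3c2CCCC3)c1`: in an ADME assay on BHK-21 cells (Mesocricetus auratus) for cytotoxicity, read by MTT assay, with a stated time of 96 h (on this read-out lower numbers stand for higher toxicity in this test and higher numbers for lower toxicity in this test), compound 1 gives 14000 nM.
Compound 2, `FC(F)(F)c1cccc(N(C[C@@H]2CCCN3CCCC[C@H]23)/N=N/c2ccccc2)c1`: in this assay compound 2 gives 40000 nM.
Compound 3, `COc1ccc(/N=N/N2CCCC2)cc1`: in this assay compound 3 gives >= 100000 nM, which is a limit of the measurement and not a number.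

Among the two full numbers, compound 1 stands at the lower one, and compound 2 stands at a higher number, a gap that lies beyond the usual scatter of repeated measurements. Compound 3 sits at the limit of >= 100000 nM in this assay, at which 1 of the 3 values shown sits, so of it only a limit is known.

The compound still to be measured is compound 4, `Fc1ccc(/N=N/c2ccc(NC[C@@H]3CCCN4CCCC[C@H]34)c3c2CCCC3)c(F)c1`. It differs from compound 1 in one place: 2,4-difluorophenyl in place of 3-(trifluoromethyl)phenyl on a double-bonded nitrogen. The rest of the molecule, the shared core with its amine side chain, is unchanged.

Among the compounds with values here, no pair of measured compounds differs in just this kind of swap, so there is no measured step to lean on. Both groups are small fluorinated aryl rings of similar size, and the expectation is that the number for compound 4 lands close to that of compound 1, with the step of a 1.3-fold higher number from compound 1 to compound 4 (0.11 log units; within the scatter) expected to stay within the usual scatter. In this assay compound 4 is therefore estimated at 18000 nM, with a range from 7000 nM to 45000 nM.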

Compound 4, half-maximal cytotoxic concentration: 9000 nM
For compound 4 the middle estimate is 2.0-fold (0.30 log units) above the measured one, within the range that was stated.
By their numbers in this assay, from the lowest: compounds 4 and 1 (each within the scatter of the next); then compound 2. At a limit, above all of these: compound 3.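

In this assay, putting 2,4-difluorophenyl in place of 3-(trifluoromethyl)phenyl on a double-bonded nitrogen gives a 1.6-fold lower number from compound 1 to compound 4 (0.19 log units; within the scatter) and so leaves the two compounds within the usual scatter of repeated measurements. Within the data shown here, the earlier compounds contained no pair differing in only one place, so this is the first direct reading of a single swap at this position. With the shared core and its amine side chain held constant, it shows that, in this test, these two fluorinated aryl groups cannot be told apart, and the measurements shown offer no explanation for that result.

On these data alone, the step covers only these two fluorine-bearing groups, so it remains unknown whether the read-out would stay within the scatter with an unsubstituted phenyl, a pyridine ring, or a phenyl ring carrying a carboxylic acid or an amine at this position. Among these compounds, it also remains open whether the same swap would give a similar result on a different core, since only one pair of compounds speaks to this change.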